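A Pyrrolidinyl Amide Step at the Solubility Limit

The source may hold more compounds than are shown below. What is called first, only, known or untested is meant among the compounds shown, and "the series" means these compounds.

Compound 1 `CCCN(C)C(=O)COC(=O)/C=C/c1ccc(NC(=O)C2(NC(=O)c3ccc4c(C5CCCC5)c(-c5ncc(Cl)cn5)n(C)c4c3)CCC2)cc1OCC` carries a propyl(methyl)amide at the end of its side chain. In an ADME assay for solubility (on this read-out higher numbers stand for higher solubility and lower numbers for lower solubility), compound 1 gives < 200000 ug/mL, which is a limit of the assay rather than a number (the limit of < 200000 ug/mL in this assay, at which 1 of the 2 values shown sits). Compound 2 `CCOc1cc(NC(=O)C2(NC(=O)c3ccc4c(C5CCCC5)c(-c5ncc(Cl)cn5)n(C)c4c3)CCC2)ccc1/C=C/C(=O)OCC(=O)N(C)C(C)C` differs from it by an isopropyl in place of the propyl on that amide-type nitrogen. In this assay compound 2 gives > 200000 ug/mL, again a limit rather than a number (the limit of > 200000 ug/mL in this assay, at which 1 of the 2 values shown sits). Among the measured compounds shown here, the step of a number no lower from compound 1 to compound 2 (the limit leaves the size open) therefore shows only that the number did not fall; its size cannot be read. Compound 2 thus stands at a limit of this read-out. Every value so far shown is a limit.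

Compound 3 `CCOc1cc(NC(=O)C2(NC(=O)c3ccc4c(C5CCCC5)c(-c5ncc(Cl)cn5)n(C)c4c3)CCC2)ccc1/C=C/C(=O)OCC(=O)N1CCCC1` has not yet been measured. It differs from compound 2 by pyrrolidin-1-yl in place of isopropyl(methyl)amino on a carbonyl carbon. For the measured compounds named here, the one measured step, from compound 1 to compound 2, touches the same amide-type nitrogen but is bounded on both sides by limits and gives no size to lean on. Compound 3 is therefore expected to stay near the limit at which compound 2 sits, with an expected step of a number no higher from compound 2 to compound 3 (the limit leaves the size open) that lies within the scatter. Compound 3 is estimated at 200000 ug/mL, with a range from 100000 ug/mL to 400000 ug/mL.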

Compound 3, solubility: > 200000 ug/mL
Compound 3: no number, only a limit; the forecaster's own chance of this, stated with the estimate: 70%; the middle value lies on the limit itself.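

With pyrrolidin-1-yl on the carbonyl carbon, in this assay compound 3 gives > 200000 ug/mL, which is a limit and not a number. The earlier compounds shown here showed this side of the limit only for the open isopropyl(methyl)amino of compound 2; a five-membered non-aromatic ring at the same place now stands there too, and it does not fall back to the side on which compound 1 sits: the limit of > 200000 ug/mL in this assay, at which 2 of the 3 values shown sit. The data give a number no lower from compound 1 to compound 3 (the limit leaves the size open). Going by these compounds, the step to compound 3 from compound 2 cannot be read, so its size stays unknown.

The compounds shown leave open how compound 2 and compound 3 compare as numbers, since neither has a value that can be placed on a scale. They also leave open whether a larger ring such as piperidin-1-yl or morpholin-4-yl on the same carbonyl carbon, or a carboxylic acid in place of the whole ester side chain, would stay on this side of the limit.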